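From neopentyl to 3,3-dimethylbutyl on compound 2

The source may hold more compounds than are shown below. What is called first, only, known or untested is meant among the compounds shown, and "the series" means these compounds.

In a functional assay for inhibition, with Rattus norvegicus as the target (on this read-out higher numbers stand for weaker inhibition and lower numbers for stronger inhibition), compound 2 (`CC(C)(C)CN/C(=C\[N+](=O)[O-])Nc1cccnc1`) holds the lower of the two single numbers at 1000 nM and compound 1 (`CC(C)(C)CN/C(=C\[N+](=O)[O-])Nc1ccncc1`) reads 10000 nM on the same scale. That gap (a 10-fold lower number from compound 1 to compound 2 (1.00 log units; beyond the scatter)) comes with pyridin-3-yl in place of pyridin-4-yl on an amine nitrogen. Compound 3 (`C[C@@H](N/C(=C\[N+](=O)[O-])Nc1cccnc1)C(C)(C)C`) yields no single number (10 nM; 1000 nM (2 entries)).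

Compound 4 (`CC(C)(C)CCN/C(=C\[N+](=O)[O-])Nc1cccnc1`) keeps the pyridin-3-yl and differs from compound 2 in its chain (neopentyl in place of tert-butyl on a saturated chain carbon bound to an amine nitrogen), with neopentyl in place of tert-butyl on a saturated chain carbon bound to an amine nitrogen. Cut one bond further out, this reads neopentyl to 3,3-dimethylbutyl. Among the measured compounds shown here, the one measured step, though modest and beyond the scatter, concerns the pyridinyl group and not this chain. The entries for compound 3 lie far apart (the several entries of compound 3 in this assay, 10 nM; 1000 nM (2 entries)) and give no size for a chain change. No step beyond the scatter is therefore expected in this assay for this change. The expected step is no change at the digits printed from compound 2 to compound 4 (within the scatter) on this estimate. For compound 4 the estimate is 1000 nM with 150 nM and 6000 nM as the expected ends of its range.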

Compound 4, half-maximal inhibitory concentration: 2000 nM
Compound 4: the middle estimate sits 2.0-fold (0.30 log units) below what was measured, within the range that was stated.
By their numbers in this assay, from the lowest: compounds 2 and 4 (each within the scatter of the next); then compound 1.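

Among the compounds shown here, with compound 4, the chain on the amine nitrogen gives a readable step in this assay for the first time, the earlier step having concerned only the pyridinyl group. Neopentyl in place of tert-butyl on a saturated chain carbon bound to an amine nitrogen gives a 2.0-fold higher number from compound 2 to compound 4 (0.30 log units; within the scatter), so with pyridin-3-yl kept, the change to 3,3-dimethylbutyl cannot be told apart from the scatter. The chain of compound 3 adds no firm comparison on this point: the several entries of compound 3 in this assay, 10 nM; 1000 nM (2 entries)

The compounds shown leave open whether a longer chain, a cyclohexyl group or a terminal amine at this position would also stay within the scatter of compound 2. They also leave open whether the same chain change would read alike with the pyridin-4-yl of compound 1.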